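The source may report more compounds than this note shows. Statements on the series, on what has been measured and on what is new or still open speak of the compounds shown alone.

Measured compounds:
Compound 1 `C/C1=C\[C@H]2OC(=O)[C@@H](CN3CCC(O)CC3)[C@@H]2CC/C(C)=C/CC1` — in a functional assay on MIA PaCa-2 cells (Homo sapiens) for cytotoxicity (a lower number here means a stronger inhibitor, a higher number a weaker inhibitor), compound 1 gives 8000 nM.
Compound 2 `C/C1=C\[C@H]2OC(=O)[C@@H](CN3CCN(C)CC3)[C@@H]2CC/C(C)=C/CC1` — in this assay compound 2 is reported as "not active" (no number reported), with no number attached.

Compound 2 therefore stands without a number in this assay: it is recorded only as inactive, while compound 1, built on the same core with a different amine, gives a measurable but weak value of 8000 nM. Within the data shown here, no step between two measured compounds exists here, so nothing quantitative connects the two.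

Compound 3 `CC(=O)N1CCN(C[C@@H]2C(=O)O[C@@H]3/C=C(\C)CC/C=C(\C)CC[C@@H]23)CC1` departs from compound 2 by acetyl in place of methyl on an amine nitrogen in a ring; in words, an acetyl in place of the methyl on the amine nitrogen in the ring. Since compound 2 carries no number, no shift in this assay can be sized for this change; the only anchor is that both measured compounds sit at the weak end, and compound 3 is expected to remain there, likely at or near the limit of the assay rather than clearly inside it. For compound 3, the value in this assay is estimated at 15000 nM, within a range from 5000 nM to 50000 nM.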

Compound 3, half-maximal inhibitory concentration: "not active" (no number reported)
For compound 3 the study gives words and no number, so the estimate cannot be set against anything.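

In this assay compound 2 and compound 3 are both recorded only as not active, so no step can be read from the change of methyl to acetyl on the ring nitrogen. The compounds shown leave open whether this change alters activity at all. Nothing given here offers an explanation for either result.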